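A few compounds are considered here, and "the series" means these few. Any claim that something is new, unique, unknown or untested is made for them only; others in the source may bear on it.

Three compounds share one core and differ only in the group on the carbonyl carbon. Compound 1 is `C#CCOCC(N)C(=O)NCc1ccccc1`, compound 2 is `CC(C)(C)[C@@H](N)C(=O)NCc1ccccc1` and compound 3 is `CCC[C@H](N)C(=O)NCc1ccccc1`. In a functional assay on the whole organism (strain NMRI) for inhibition, with Mus musculus as the target, in the formalin test, with a stated time of 30 min (on this read-out higher numbers stand for an effect only at larger amounts of compound and lower numbers for an effect already at smaller amounts), compound 1 gives 74 mg/kg. Compound 2 gives only a limit of the assay in this assay, namely > 22 mg/kg, and not a number. Compound 3 gives 100 mg/kg in this assay. On the numbers shown, compound 3 stands alongside compound 1, since the gap between the two lies within the usual scatter of repeated measurements, so they cannot be told apart.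

Compound 4 is `N[C@H](CCO)C(=O)NCc1ccccc1` and has not yet been measured. From compound 3 to compound 4 the change is 1-amino-3-hydroxypropyl in place of 1-aminobutyl on a carbonyl carbon. Among the compounds with values here, no pair of measured compounds here differs in one place, so there is no measured step to rest an expectation on, and the two numbers known lie close together. The expected step in this assay, a 1.1-fold higher number from compound 3 to compound 4 (0.04 log units; within the scatter), is estimated to be no larger than the scatter, in no particular direction. Compound 4 is therefore expected to give about 110 mg/kg in this assay, with a range from 45 mg/kg to 270 mg/kg.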

Compound 4, dose for half-maximal effect: > 67 mg/kg
Compound 4: a limit, no number; the forecaster's own chance of this, stated with the estimate: 25%; the middle value lies beyond the limit too.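

In this assay compound 4 gives > 67 mg/kg, which is a limit of the assay and not a number. Compound 2 also gives only a limit, so the steps from compound 3 to compound 4 and from compound 2 to compound 4 cannot be read. The compounds shown leave open how 1-amino-3-hydroxypropyl compares with 1-aminobutyl on the shared core.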